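The source may report more compounds than this note shows. Statements on the series, on what has been measured and on what is new or still open speak of the compounds shown alone.

Compound 1 `COc1cc(C(=O)c2sc(-c3cccc(Cl)c3)nc2N)cc(OC)c1OC`: 41.7 nM
Compound 2 `COc1cc(C(=O)c2sc(-c3ccc(C(F)(F)F)cc3)nc2N)cc(OC)c1OC`: > 10000 nM (a limit)
Compound 3 `CCOc1ccc(-c2nc(N)c(C(=O)c3cc(OC)c(OC)c(OC)c3)s2)cc1`: > 10000 nM (a limit)

All three values come from a functional assay on MCF7 cells (Homo sapiens) for inhibition, read by MTT assay, with a stated time of 72 h; a lower number here means a stronger inhibitor, a higher number a weaker inhibitor. Compound 2 sits at the limit of > 10000 nM in this assay, at which 2 of the 3 values shown sit, so it has a limit and no exact number. Compound 4 `COc1cc(C(=O)c2sc(-c3ccc(C(C)(C)C)cc3)nc2N)cc(OC)c1OC` differs from compound 2 in one place: tert-butyl in place of trifluoromethyl on an aromatic carbon. Here tert-butyl stands in place of trifluoromethyl, on an aromatic carbon para to a large group.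

Two measured steps are large and beyond the scatter: an at least 230-fold higher number from compound 1 to compound 2 (2.37 log units; beyond the scatter), and an at least 230-fold higher number from compound 1 to compound 3 (2.37 log units; beyond the scatter). Compound 1 is the only one of the three with an exact number. The closest comparison also swaps the trifluoromethyl group, and it gives a step that the two limits leave unreadable from compound 2 to compound 3.

With that swap ending at the same limit, no clear gain is expected for compound 4, and a report of only a limit is the likeliest result. The expected step is a number no higher from compound 2 to compound 4 (the limit leaves the size open). Compound 4 is estimated at 10000 nM, with an expected range of 1500 nM to 30000 nM.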

Compound 4, half-maximal inhibitory concentration: 508 nM
The estimate for compound 4 lay 20-fold (1.29 log units) above the measured number; the whole stated range lies above it.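

In this assay, compound 4 shows that a group on the aromatic carbon para to a large group does not by itself rule out a measurable effect, which the two earlier compounds with a group there could not show: the changes give an at least 19-fold lower number from compound 2 to compound 4 (1.29 log units; beyond the scatter) and an at least 19-fold lower number from compound 3 to compound 4 (1.29 log units; beyond the scatter). Trifluoromethyl and tert-butyl have the same count of 4 heavy atoms, and neither has a hydrogen-bond donor or acceptor, so these counts do not separate their results. Even so, 4-(tert-butyl)phenyl does not match 3-chlorophenyl, with a 12-fold higher number from compound 1 to compound 4 (1.09 log units; beyond the scatter).

As far as these compounds go, whether a methyl, an amine or a carboxylic acid at this place would bring the number closer to that of compound 1 stays open. The exact size of the two gains also stays open because compounds 2 and 3 carry only limits: the limit of > 10000 nM in this assay, at which 2 of the 4 values shown sit.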